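This account rests on a few compounds, and the source may have more. Where it says the series, first, only, none or still open, it means among the compounds named here.

Measured compounds in a functional assay on HEK293 cells for antagonist activity at corticotropin-releasing factor receptor 1 (Homo sapiens), read by fluorescence and cAMP accumulation, with a stated time of 30 min; a higher number here means a weaker inhibitor, a lower number a stronger inhibitor:
Compound 1 `COCc1cc(OC)c(-c2cccc3c(N(CC4CCOCC4)CC4CC4)c(C)nn23)c(OC)c1`; compound 1 gives 50 nM.
Compound 2 `COCc1cc(OC)c(-c2cccc3c(N(CC4CCOCC4)CC4CC4)c(C#N)nn23)c(OC)c1`; compound 2 gives 52 nM.
Compound 3 `CCc1nn2c(-c3c(OC)cc(COC)cc3OC)cccc2c1N(CC1CCOCC1)CC1CC1`; compound 3 gives 23 nM.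

Compound 3 stands lowest of the three in this assay: a 2.2-fold lower number from compound 1 to compound 3 (0.34 log units; beyond the scatter) and a 2.3-fold lower number from compound 2 to compound 3 (0.35 log units; beyond the scatter) are both beyond the scatter, whereas a 1.0-fold higher number from compound 1 to compound 2 (0.02 log units; within the scatter) lies within it. Compound 4 `COCc1cc(OC)c(-c2cccc3c(N(CC4CCOCC4)CC4CC4)c(SC)nn23)c(OC)c1` differs from compound 3 by methylsulfanyl in place of ethyl on an aromatic carbon. Within the data shown here, no measured pair puts methylsulfanyl against ethyl on this aromatic carbon, so the bearing steps are only indirect ones: the two measured changes at this carbon, a 2.2-fold lower number from compound 1 to compound 3 (0.34 log units; beyond the scatter) and a 2.3-fold lower number from compound 2 to compound 3 (0.35 log units; beyond the scatter), were modest, and the three numbers fall within a narrow band. A further change at the same aromatic carbon is therefore expected to move the number only modestly, most likely upward from compound 3 toward compound 1 and compound 2, but possibly not beyond the scatter at all. Compound 4 is expected to give about 35 nM in this assay, between 15 nM and 90 nM. This estimate amounts to a 1.5-fold higher number from compound 3 to compound 4 (0.18 log units; within the scatter).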

Compound 4, half-maximal inhibitory concentration: 30 nM
The estimate for compound 4 lay 1.2-fold (0.07 log units) above the measured number; the range from low to high includes it.
By their numbers in this assay, from the lowest: compounds 3, 4, 1 and 2 (each within the scatter of the next, the first and the last beyond it).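

In this assay, a 1.3-fold higher number from compound 3 to compound 4 (0.12 log units; within the scatter) lies within the scatter, so methylsulfanyl, which has the same count of heavy atoms as ethyl but brings a sulfur and a hydrogen-bond acceptor, cannot be told apart from ethyl on this aromatic carbon. Likewise, a 1.7-fold lower number from compound 2 to compound 4 (0.24 log units; within the scatter) and a 1.7-fold lower number from compound 1 to compound 4 (0.22 log units; within the scatter) both lie within the scatter. Thus, whereas ethyl stood apart from cyano and methyl by steps beyond the scatter, methylsulfanyl stands apart from none of these three groups at this position.

The compounds shown leave open whether a longer chain such as propyl, an amine or a carboxylic acid on this carbon would move the number beyond the scatter. No supporting evidence is available to explain any of these steps.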